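Swapping isopropyl for 2-methoxyethyl: what happens to rat clearance?

The compounds below may be only part of what the source reports. "The series", "measured", "known", "first", "only" and "open" are said of these compounds alone.

Three compounds share one core and differ only in the group on an amide-type nitrogen in a ring. They are followed here in an ADME assay on the whole organism for pharmacokinetics, with Rattus norvegicus as the target, at a dose of 2 mg/kg by the intravenous route (a lower number here means slower removal, a higher number faster removal of the compound), which tracks how quickly the body clears a compound from the blood. For compound 1 `Cc1nc(-c2nc[nH]n2)ccc1-c1cnc2c(n1)N(CC1CCOCC1)C(=O)CN2`, which carries a larger group at that place, the entry reads "not determined" (no result reported). Among the measured compounds shown here, compound 2 `Cc1nc(-c2nc[nH]n2)ccc1-c1cnc2c(n1)N(C(C)C)C(=O)CN2` gives 6.97 mL/min/kg, the only number available, so it cannot yet be ranked against anything.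

Compound 3 `COCCN1C(=O)CNc2ncc(-c3ccc(-c4nc[nH]n4)nc3C)nc21` has not been measured. It puts 2-methoxyethyl in place of isopropyl on an amide-type nitrogen in a ring. For the measured compounds named here, no measured pair shows what a change at this place does, so the expectation stays anchored on compound 2 at 6.97 mL/min/kg and has to stay cautious. The expected step of a 1.6-fold higher number from compound 2 to compound 3 (0.20 log units; within the scatter) is a small rise that would remain within the usual scatter of this assay, though the direction is far from certain. For compound 3 the estimated clearance is 11 mL/min/kg, with an expected range of 5 mL/min/kg to 24 mL/min/kg.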

Compound 3, clearance: 34.7 mL/min/kg
The estimate for compound 3 lay 3.2-fold (0.50 log units) below the measured number, and the stated range ends below it.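

Replacing isopropyl with 2-methoxyethyl on an amide-type nitrogen in a ring produces a 5.0-fold higher number from compound 2 to compound 3 (0.70 log units; beyond the scatter) in this assay, the first sign that this position matters for how fast the compound is removed. The change is small on paper: the entering chain has one hydrogen-bond acceptor where isopropyl has none, its additional heavy atom is an oxygen, and neither group has a ring or a net charge. So a modest edit at this place is enough to move clearance well past the usual scatter, although nothing measured here explains the rise.

Among the compounds shown here, with only one step, it remains unclear whether the oxygen or the longer chain accounts for the change, and an all-carbon butyl chain or a chain ending in an amine on the same nitrogen would help separate those possibilities. For compound 1, with its larger group at this place, the entry stays "not determined" (no result reported), so the pair of compound 2 and compound 3 cannot show whether this rise extends to other oxygen-bearing groups.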